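A few compounds are considered here, and "the series" means these few. Any claim that something is new, unique, unknown or untested is made for them only; others in the source may bear on it.

Measured in a physicochemical assay for metabolic stability, read by HPLC and mass spectrometry, in phosphate buffer, at 37 degrees C, at pH 7.4; on this read-out higher numbers stand for a longer-lived compound and lower numbers for a shorter-lived compound:
- Compound 1 `CC(C)(O/N=C(\C(=O)N[C@@H]1C(=O)N(S(=O)(=O)O)[C@@H]1CN1CCC1=O)c1csc(N)n1)C(=O)O`: > 1000 h (a limit)
- Compound 2 `CC(C)(O/N=C(\C(=O)N[C@@H]1C(=O)N(S(=O)(=O)O)[C@@H]1CN1CCCC1=O)c1csc(N)n1)C(=O)O`: > 1000 h (a limit)
- Compound 3 `CC(C)(O/N=C(\C(=O)N[C@@H]1C(=O)N(S(=O)(=O)O)[C@@H]1CN1C[C@H](CN)OC1=O)c1csc(N)n1)C(=O)O`: > 37 h (a limit)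

None of the three results is a number; each is a limit of this assay. Compound 3 stands at > 37 h, and this too is only a limit.

Compound 4 `CC(C)(O/N=C(\C(=O)N[C@@H]1C(=O)N(S(=O)(=O)O)[C@@H]1CN1C[C@H](CNC(=N)N)OC1=O)c1csc(N)n1)C(=O)O` differs from compound 3 in a single place: a group of 3 heavy atoms (1 carbon, 2 nitrogen; no ring) in place of a hydrogen atom, on an amine nitrogen. Within the data shown here, no measured compound carries this group, so no measured step speaks to the change directly. The closest evidence comes from changes to the group on the saturated chain carbon. These are a step that the two limits leave unreadable from compound 1 to compound 2, a step that the two limits leave unreadable from compound 1 to compound 3 and a step that the two limits leave unreadable from compound 2 to compound 3. None of them offers a size that could be carried over, and none offers a direction.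

With so little to go on, no change beyond the usual scatter is expected, and the estimate stays close to the only reference point for the aminomethyl compound. The expected change is a step that the limit leaves unreadable from compound 3 to compound 4. Compound 4 is estimated at 60 h, with an expected range from 30 h to 400 h.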

Compound 4, half-life: > 37 h
Compound 4 ended at the assay's limit (the forecaster's own chance of this, stated with the estimate: 55%); the middle value does not contradict the limit.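

The result for compound 4 adds no readable step: in this assay the results for compound 1, compound 2, compound 3 and compound 4 are all limits, so none of the steps linking compound 4 to the others can be read. The compounds shown leave open the actual half-life of each compound, and whether the group entering on the amine nitrogen of compound 4 shifts it in either direction.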